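Fluoro Gives Way to Hydrogen at the Assay Limit

The compounds below may be only part of what the source reports. "The series", "measured", "known", "first", "only" and "open" are said of these compounds alone.

Three related compounds have been measured in a functional assay on MIA PaCa-2 cells (Homo sapiens) for cytotoxicity, read by WST assay, with a stated time of 24 h; on this read-out higher numbers stand for weaker inhibition and lower numbers for stronger inhibition. Compound 1 (`N#C/C(=C\c1cn(Cc2ccc(Cl)cc2)c2ccc(Br)cc12)C(=O)c1c[nH]c2ccccc12`) gives 37700 nM, and compound 3 (`COc1ccc(-c2[nH]c3ccccc3c2/C=C(\C#N)C(=O)c2c[nH]c3ccccc23)cc1`) gives 24000 nM. Compound 2 (`N#C/C(=C\c1cn(Cc2ccc(Cl)cc2)c2ccccc12)C(=O)c1c[nH]c2cc(F)ccc12`) returns only a limit, > 50000 nM, and not a number. Compound 2 thus stands at the limit of > 50000 nM in this assay, at which 1 of the 3 values shown sits.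

Compound 4 (`N#C/C(=C\c1cn(Cc2ccc(Cl)cc2)c2ccccc12)C(=O)c1c[nH]c2ccccc12`) awaits measurement and differs from compound 2 in one place: hydrogen in place of fluoro on an aromatic carbon. This is hydrogen in place of fluoro on an aromatic carbon, so 6-fluoro-1H-indol-3-yl becomes 1H-indol-3-yl. Among the compounds with values here, no measured pair in this assay shows this change alone. The expectation therefore rests on related compounds that do give numbers, namely compound 1 at 37700 nM and compound 3 at 24000 nM. A small step toward stronger inhibition is expected, and it may stay within the scatter: the estimated change is an at least 1.4-fold lower number from compound 2 to compound 4 (0.15 log units; that floor lies within the scatter). Compound 4 is estimated at 35000 nM, with an expected range of 15000 nM to 60000 nM.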

Compound 4, half-maximal inhibitory concentration: > 50000 nM
Compound 4: only a limit was reported (the forecaster's own chance of this, stated with the estimate: 35%); at least 1.4-fold (0.15 log units) between middle value and limit.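

With the fluoro gone, 1H-indol-3-yl does no better than 6-fluoro-1H-indol-3-yl in this assay: neither compound gives a number, so the step between them cannot be read, and this change remains without a measured size. Within the data shown here, the one readable step concerns a different place, where hydrogen stands in place of bromo on an aromatic carbon: an at least 1.3-fold higher number from compound 1 to compound 4 (0.12 log units; that floor lies within the scatter), so losing the bromo cannot be said to weaken inhibition. The limit now marks compound 2 and compound 4 alike: the limit of > 50000 nM in this assay, at which 2 of the 4 values shown sit.

As far as these compounds go, what the fluoro contributes remains open, since a real number for either compound would be needed to size this change. Also open, from the compounds shown here alone, is whether an amine or a carboxylic acid in the place of the fluoro would bring the compound down from the limit.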